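Anilinoenone series on keratinocyte antiproliferation: methoxy for chloro

A few compounds are considered here, and "the series" means these few. Any claim that something is new, unique, unknown or untested is made for them only; others in the source may bear on it.

Measured so far:
Compound 1, `O=C(/C=C\Nc1ccc(F)cc1)c1cn(-c2ccccc2)nc1-c1ccccc1`: 34200 nM
Compound 2, `O=C(/C=C\Nc1ccc(Cl)cc1)c1cn(-c2ccccc2)nc1-c1ccccc1`: 28400 nM
Compound 3, `O=C(/C=C\Nc1ccc(Cl)cc1)c1cn(-c2ccccc2)nc1-c1ccc(F)cc1`: 21300 nM

In an ADME assay on HaCaT cells (Homo sapiens) for antiproliferative activity, read by MTT assay, with a stated time of 48 h (a higher number here means a weaker inhibitor, a lower number a stronger inhibitor), compound 3 gives the lowest of the three numbers, yet its steps to compound 2 and compound 1 both lie within the scatter. Compound 4, `COc1ccc(N/C=C\C(=O)c2cn(-c3ccccc3)nc2-c2ccc(F)cc2)cc1`, differs from compound 3 by methoxy in place of chloro on an aromatic carbon. Going by the values given here, the nearest precedent is a 1.2-fold lower number from compound 1 to compound 2 (0.08 log units; within the scatter), a change on the same aromatic carbon, and a 1.3-fold lower number from compound 2 to compound 3 (0.12 log units; within the scatter) was likewise small; neither halogen exchange moved this assay beyond the scatter. Among the compounds with values here, no methoxy analogue is among the measured compounds. Compound 4 is therefore expected to sit close to compound 3, with a 1.0-fold higher number from compound 3 to compound 4 (0.01 log units; within the scatter), so its estimate is 22000 nM within 10000 nM to 48000 nM.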

Compound 4, half-maximal inhibitory concentration: 19600 nM
Beside the measured number, compound 4's estimate is 1.1-fold (0.05 log units) above it; low and high end bracket the measured number.
By their numbers in this assay, from the lowest: compounds 4, 3, 2 and 1 (each within the scatter of the next).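

Until now this aromatic carbon had carried only fluoro and chloro. In this assay the exchange of chloro for methoxy, which brings one more heavy atom and a hydrogen-bond acceptor, gives a 1.1-fold lower number from compound 3 to compound 4 (0.04 log units; within the scatter) and so shows that a group other than a halogen at this carbon also stays within the scatter. No evidence available here bears on this result.
As far as these compounds go, whether an amine, a carboxylic acid or a longer alkoxy chain at this carbon would also stay within the scatter remains open. So does whether methoxy would read the same without the fluoro group of compound 3.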